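Adding a hydroxymethyl group on the ring-nitrogen substituent of compound 2

The compounds below may be only part of what the source reports. "The series", "measured", "known", "first", "only" and "open" are said of these compounds alone.

Three compounds sharing one core have been examined in a functional assay on the whole organism with Mus musculus as the target, in the writhing test; a higher number here means that more compound is needed for the effect, a lower number that less compound is needed. Compound 2 `Cc1cc(=O)oc2c1c(C)nn2C` is the only one with a numeric result: in this assay compound 2 gives 11.6 mg/kg. Compound 1 `CCCCn1nc2oc(=O)cc(C)c2c1C` carries a butyl chain on the ring nitrogen; in this assay compound 1 gives > 100 mg/kg, which is a limit of the assay and not a number. Compound 3 `Cc1cc(=O)oc2c1c(CC(=O)O)nn2C` carries a carboxy group on a saturated chain carbon bound to an aromatic carbon; in this assay compound 3 gives > 100 mg/kg, again a limit rather than a number. Within the data shown here, the one step that can be sized, an at least 8.6-fold higher number from compound 2 to compound 3 (0.93 log units; beyond the scatter), shows that compound 2 is the only point with a measured dose, while the other two sit at the limit of > 100 mg/kg in this assay, at which 2 of the 3 values shown sit.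

Compound 4 `Cc1cc(=O)oc2c1c(C)nn2CCO` differs from compound 2 by hydroxymethyl in place of hydrogen on a saturated chain carbon bound to an aromatic nitrogen, the same difference read one bond further out being methyl to 2-hydroxyethyl. Among the measured compounds shown here, no measured step concerns this exact place, but the step from compound 2 to compound 3 and the limit of compound 1 both show that adding to compound 2 has so far cost activity. A modest rise in dose is therefore expected, a 2.6-fold higher number from compound 2 to compound 4 (0.41 log units; beyond the scatter), and compound 4 is estimated to give 30 mg/kg in this assay, within 10 mg/kg to 100 mg/kg.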

Compound 4, dose for half-maximal effect: 100 mg/kg
For compound 4 the middle estimate is 3.3-fold (0.52 log units) below the measured one; low and high end bracket the measured number.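

In this assay, the place on a saturated chain carbon bound to an aromatic nitrogen now has a change of known size: hydroxymethyl in place of hydrogen gives an 8.6-fold higher number from compound 2 to compound 4 (0.94 log units; beyond the scatter). Among these compounds, until now, the only other change to this substituent was the butyl chain of compound 1, which gives > 100 mg/kg, a limit of the assay and not a number, so no step to or from compound 1 can be read. Compound 4 shows that a 2-hydroxyethyl group here still gives a measured dose, though its figure matches the number in the limit reached by two other compounds: the limit of > 100 mg/kg in this assay, at which 2 of the 4 values shown sit.

The compounds shown leave open whether this rise goes with the hydroxyl group or with the longer chain alone, and an ethyl or propyl chain at this place, carrying no oxygen, would separate the two. They also leave open how a chain ending in an amine or a carboxylic acid at this place would read in this assay.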